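Indolyl piperidine ureas: carbamoyl in place of fluoro

A few compounds are considered here, and "the series" means these few. Any claim that something is new, unique, unknown or untested is made for them only; others in the source may bear on it.

Compound 1 `COc1ccc(NC(=O)N2CCC(c3c[nH]c4cc(F)ccc34)CC2)cc1N1CCN(C)CC1` gives 200 nM in an assay on frontal cortex for binding affinity to 5-hydroxytryptamine receptor 1D (Rattus norvegicus), read by radioligand binding (on this read-out higher numbers stand for weaker inhibition and lower numbers for stronger inhibition), the lowest of the two numbers in hand. Compound 2 `COc1ccc(NC(=O)N2CCN(CCCCc3c[nH]c4ccc(F)cc34)CC2)cc1N1CCN(C)CC1` gives 367 nM in this assay, a difference from compound 1 that lies within the scatter, so the two stand together. Compound 3 `COc1ccc(NC(=O)N2CCC(c3c[nH]c4ccc(C(N)=O)cc34)CC2)cc1N1CCN(C)CC1` has not been measured in this assay. It differs from compound 1 by 5-carbamoyl-1H-indol-3-yl in place of 6-fluoro-1H-indol-3-yl on a saturated ring carbon. Among the measured compounds shown here, no measured pair shows this change, so the step of a 2.0-fold lower number from compound 1 to compound 3 (0.30 log units; within the scatter) is an expectation only, towards a lower number and at most modestly beyond the scatter. For compound 3 the estimate in this assay is 100 nM, within 30 nM to 300 nM.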

Compound 3, half-maximal inhibitory concentration: 100 nM
Compound 3: middle estimate and measured number agree at the digits printed, within the range that was stated.
By their numbers in this assay, from the lowest: compounds 3, 1 and 2 (each within the scatter of the next, the first and the last beyond it).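

In this assay, the step of a 2.0-fold lower number from compound 1 to compound 3 (0.30 log units; within the scatter) shows that this place on the saturated ring carbon accepts 5-carbamoyl-1H-indol-3-yl as well as 6-fluoro-1H-indol-3-yl, with the two numbers standing together. Affinity in this series therefore does not depend on the fluoro group, and a carbamoyl group with its added hydrogen-bond donor is accommodated. Nothing available explains this result. The step changes both the group and its place on the indolyl, so the two contributions stay unseparated. On these data alone, whether 5-fluoro-1H-indol-3-yl, 5-cyano-1H-indol-3-yl or 5-carboxy-1H-indol-3-yl would hold the same number remains open.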